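The source may hold more compounds than are shown below. What is called first, only, known or untested is meant among the compounds shown, and "the series" means these compounds.

In an assay on isolated protein for inhibition of DNA topoisomerase 1 (Homo sapiens), with a stated time of 15 min (a higher number here means a weaker inhibitor, a lower number a stronger inhibitor), compound 3 `O=C(O)c1cn(Cc2ccc(-c3ccccc3)cc2)c2cc(N3CC4CNCC4C3)c(F)cc2c1=O` gives 33300 nM, the lowest of the three numbers; compound 1 `O=C(O)c1cn(Cc2ccc(-n3cccn3)cc2)c2cc(N3CC4CNCC4C3)c(F)cc2c1=O` gives 173000 nM and compound 2 `COc1c(N2CC[C@@H](CN)C2)c(F)cc2c(=O)c(C(=O)O)cn(Cc3cc(-c4ccccc4)no3)c12` gives 178000 nM, each beyond the scatter from compound 3. Compound 4 `O=C(O)c1cn(Cc2ccc(-c3ccccc3)cc2)c2cc(N3C[C@H]4CCNC[C@H]4C3)c(F)cc2c1=O` differs from compound 3 in one place: a group of 9 heavy atoms (7 carbon, 2 nitrogen; one five-membered non-aromatic ring with 1 hetero atom, one six-membered non-aromatic ring with 1 hetero atom) in place of a group of 8 heavy atoms (6 carbon, 2 nitrogen; 2 five-membered non-aromatic rings with 1 hetero atom each), on an aromatic carbon. Going by the values given here, the only measured step, a 5.2-fold lower number from compound 1 to compound 3 (0.72 log units; beyond the scatter), changes a different part of the molecule, so no measured step bears on this exchange of the ring group on that aromatic carbon. With nothing to point either way, the expected step is of no clear direction and within the scatter, a 1.0-fold lower number from compound 3 to compound 4 (0.00 log units; within the scatter). Compound 4 is therefore estimated in this assay at 33000 nM, with a range from 8000 nM to 130000 nM.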

Compound 4, half-maximal inhibitory concentration: 61000 nM
Beside the measured number, compound 4's estimate is 1.8-fold (0.27 log units) below it; measured number inside the range.
By their numbers in this assay, from the lowest: compounds 3 and 4 (each within the scatter of the next); then compounds 1 and 2 (each within the scatter of the next).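

Going by these compounds alone, at the aromatic carbon ortho to a fluoro group, the ring group had not yet been varied. In this assay, putting a group of 9 heavy atoms, with one five-membered and one six-membered non-aromatic ring, in place of the group of 8 heavy atoms with two five-membered rings gives a 1.8-fold higher number from compound 3 to compound 4 (0.26 log units; within the scatter), so this exchange leaves no change that can be told from the scatter. Nothing available gives a reason for this outcome. Still open, as far as these compounds go, is how a piperazine ring at this carbon would read, and whether the other stereoisomers of the entering group would read the same.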